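Shifting a fluorine on the outer ring of compound 2

This account rests on a few compounds, and the source may have more. Where it says the series, first, only, none or still open, it means among the compounds named here.

For the measured compounds named here, compound 2 `CC(C)C[C@H](N)CN(C(=O)[C@@H]1C[C@H]1c1ccccc1)c1ccc(-c2ccc(F)cc2)cc1` gives the lowest of the two numbers so far: in a functional assay for agonist activity at G protein-coupled receptor 88 (Homo sapiens), read by HTRF and cAMP accumulation (on this read-out lower numbers stand for an effect already at smaller amounts and higher numbers for an effect only at larger amounts of compound), compound 2 gives 900 nM, while compound 1 `CC(C)C[C@H](N)CN(C(=O)[C@@H]1C[C@H]1c1ccccc1)c1ccc(C2=CCCCC2)cc1` gives 1200 nM, a gap of a 1.3-fold lower number from compound 1 to compound 2 (0.12 log units; within the scatter). Compound 3 `CC(C)C[C@H](N)CN(C(=O)[C@@H]1C[C@H]1c1ccccc1)c1ccc(-c2ccccc2F)cc1` differs from compound 2 by 2-fluorophenyl in place of 4-fluorophenyl on an aromatic carbon. Going by the values given here, no measured step concerns moving a fluorine within this ring; the single measured step, a 1.3-fold lower number from compound 1 to compound 2 (0.12 log units; within the scatter), swaps a whole group and stays within the scatter. Compound 3 is therefore expected to show a 1.2-fold higher number from compound 2 to compound 3 (0.09 log units; within the scatter), nothing beyond the scatter. Compound 3 is estimated at 1100 nM, between 400 nM and 3000 nM.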

Compound 3, half-maximal effective concentration: 1600 nM
Estimate against measurement, compound 3: 1.5-fold (0.16 log units) below, within the range that was stated.
By their numbers in this assay, from the lowest: compounds 2, 1 and 3 (each within the scatter of the next).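

Moving the fluorine, with the same atoms joined differently, gives a 1.8-fold higher number from compound 2 to compound 3 (0.25 log units; within the scatter) in this assay, so no effect of its place on the outer ring can be read from this pair. Replacing cyclohex-1-en-1-yl with 2-fluorophenyl gives a 1.3-fold higher number from compound 1 to compound 3 (0.12 log units; within the scatter), so the three groups tried on this aromatic carbon cannot yet be told apart. No supporting data bear on these small differences. Still open, from the compounds shown here alone, is how 3-fluorophenyl would compare. Also open, going by these compounds, is whether an outer ring carrying an amine or a carboxylic acid, or a plain hexyl chain in its place, would move the number beyond the scatter.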